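This account rests on a few compounds, and the source may have more. Where it says the series, first, only, none or still open, it means among the compounds named here.

Compound 1 `CCCCC(=O)N(Cc1ccc(OC)c(O)c1)c1cc(OC)c(OC)c(OC)c1` is the reference point. In a functional assay on KYSE-450 cells (Homo sapiens) for inhibition, read by MTT assay, with a stated time of 48 h (on this read-out lower numbers stand for stronger inhibition and higher numbers for weaker inhibition), compound 1 gives 300 nM, the lower of the two numbers available. Going by the values given here, the only other measured compound, compound 2 `COc1ccc(N(Cc2cc(OC)c(OC)c(OC)c2)C(=O)CN=[N+]=[N-])cc1O`, gives 26100 nM in this assay, a gap well beyond the scatter; its structure differs in several places, so it offers no single-change comparison.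

Compound 3 `COc1ccc(CN(C(=O)CBr)c2cc(OC)c(OC)c(OC)c2)cc1O` changes one place of compound 1: bromo in place of propyl on a saturated chain carbon bound to a carbonyl carbon. Nothing measured isolates such a change, so the expected step of a 3.3-fold higher number from compound 1 to compound 3 (0.52 log units; beyond the scatter) in this assay is tentative, leaning toward a weaker result. For compound 3 the estimate in this assay is 1000 nM, within a range from 200 nM to 6000 nM.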

Compound 3, half-maximal inhibitory concentration: 120 nM
The estimate for compound 3 lay 8.3-fold (0.92 log units) above the measured number, and the stated range ends above it.
By their numbers in this assay, from the lowest: compound 3; then compound 1; then compound 2.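

At this position, the propyl of compound 1 is not needed for activity. In this assay, putting bromo in its place on a saturated chain carbon bound to a carbonyl carbon gives a 2.5-fold lower number from compound 1 to compound 3 (0.40 log units; beyond the scatter), a modest gain from a group with fewer heavy atoms. No measurement shown here explains this gain.

On these data alone, it remains open whether the gain comes from the bromine itself or from the loss of propyl. Chloro or plain hydrogen in this place could separate the two, while an amine or a longer chain would test how much variety the position accepts.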